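Hydroxymethyl in place of methyl on a furan-bearing imidazoline

This account rests on a few compounds, and the source may have more. Where it says the series, first, only, none or still open, it means among the compounds named here.

Of the compounds shown here, three have been measured in a functional assay for inhibition of Monoamine oxidase (Rattus norvegicus), tested at 10 uM; on this read-out lower numbers stand for a weaker effect and higher numbers for a stronger effect at the one concentration tested. Compound 1, `C(=C/c1ccccc1)\C1=NCCN1`, gives 25%. Compound 2, `c1cnc2ccc(C3=NCCN3)cc2c1`, gives 0%. Compound 3, `CC1CN=C(c2ccc(-c3ccccc3)o2)N1`, gives 55%, which is the highest of the three numbers: it stands above compound 1 by a gap beyond the usual scatter and above compound 2 by a larger gap, also beyond the scatter. On these numbers compound 3 is the strongest of the three.

The next compound, compound 4, `OCC1CN=C(c2ccc(-c3ccccc3)o2)N1`, differs from compound 3 in one place only: hydroxy in place of hydrogen on a saturated chain carbon bound to a saturated ring carbon. Among the measured compounds shown here, no pair among the measured compounds shows the effect of this particular change, so there is nothing measured to lean on for its direction. What can be said is that the shared core of compound 3 and compound 4 is otherwise untouched, and the change is a small one in size. A step in this assay of modest size is therefore expected, quite possibly within the scatter, and if anything a slight loss rather than a gain. The estimate for compound 4 is 45%, with a range from 15% to 70%, which would mean an expected step of a number 10 percentage points lower from compound 3 to compound 4 (within the scatter).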

Compound 4, a percentage reported as inhibition, at one concentration (the size of the read-out at that concentration, not a potency): 25%
Estimate against measurement, compound 4: 20 percentage points above, within the range that was stated.
By their numbers in this assay, from the lowest: compound 2; then compounds 1 and 4 (each within the scatter of the next); then compound 3.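

In this assay, among the compounds shown here, compound 3 and compound 4 form the first measured pair that differs in one place, and the change from methyl to hydroxymethyl gives a number 30 percentage points lower from compound 3 to compound 4 (beyond the scatter). This shows that the position is sensitive: hydroxy in place of hydrogen on a saturated chain carbon bound to a saturated ring carbon adds only one heavy atom, yet it moves the read-out by more than repeated measurements would be expected to, while compound 4 still retains 25%. So at this one concentration the change weakens the effect without abolishing it, but no separate measurement bears on the reason for the drop.

The compounds shown leave open whether this loss belongs to the hydroxy group itself or would follow other groups at this place, such as methoxymethyl, aminomethyl or a carboxylic acid. They also leave open whether a longer chain, such as ethyl, would be tolerated here, and whether the step from methyl to hydroxymethyl would have the same direction and size on a different core.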